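Enantiomer Swap on a Carbamate-Bearing Lactone

The source may report more compounds than this note shows. Statements on the series, on what has been measured and on what is new or still open speak of the compounds shown alone.

The series comprises two compounds with measured values and one awaiting measurement. Compound 1 `C=C1C(=O)OC[C@@H]1CCOC(=O)Nc1ccc(I)cc1` and compound 2 `C=C1C(=O)OC[C@H]1CCOC(=O)Nc1c(C)cccc1C(C)C` share a core carrying a carbamate and differ in the substituents on the aryl ring. In an ADME assay on RAW264.7 cells (Mus musculus) for cytotoxicity, read by MTT assay, with a stated time of 18 h (on this read-out lower numbers stand for higher toxicity in this test and higher numbers for lower toxicity in this test), compound 1 gives 12500 nM, and compound 2 gives 22200 nM; the two values lie within the usual scatter of each other, so no ranking between them can be drawn from this pair.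

Compound 3 `C=C1C(=O)OC[C@@H]1CCOC(=O)Nc1c(C)cccc1C(C)C` is the other enantiomer of compound 2: the two compounds have the same atoms and bonds and differ only in configuration as drawn: 1 of 1 stereo elements differ; a stereocentre at a saturated ring carbon is drawn S in compound 2 and R in compound 3. Among the compounds with values here, no measured pair in this set changes only configuration, so nothing here shows how large a step such a change produces in this assay. The value of compound 3 is therefore expected to stay close to that of compound 2, with a step of a 1.1-fold lower number from compound 2 to compound 3 (0.05 log units; within the scatter) that is estimated to lie within the scatter in either direction. For compound 3 the estimate in this assay is 20000 nM, with a range from 8000 nM to 50000 nM.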

Compound 3, half-maximal cytotoxic concentration: > 50000 nM
Compound 3 was reported as a limit; the forecaster's own chance of this, stated with the estimate: 10%; at least 2.5-fold (0.39 log units) between middle value and limit.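

Within the data shown here, changing the saturated ring carbon from S to R produces something no earlier pair could show: in this assay configuration alone gives a step readable as an at least 2.2-fold higher number from compound 2 to compound 3 (0.35 log units; beyond the scatter), which lies beyond the scatter. For compound 3 the reading > 50000 nM is a limit of the assay and not a number, so the full size of the step stays unread. The step can be assigned to configuration alone because of one fact: the fact that compounds 2 and 3 differ only in the configuration as drawn.

From the compounds shown here alone, whether the other enantiomer of compound 1 would show a step of this kind remains open. Also open, going by these compounds, is how a compound with an amine or a carboxylic acid on the aryl ring would read in this assay, and whether configuration would matter to the same degree there.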